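This account rests on a few compounds, and the source may have more. Where it says the series, first, only, none or still open, it means among the compounds named here.

Measured compounds:
- compound 1 `Cc1cccc(NC(=O)CN2CCN(c3cccc4ccccc34)CC2)c1`: 27.8%
- compound 2 `Cc1cccc(NC(=O)CN2CCN(c3ccc(Cl)cn3)CC2)c1`: "not active" (no number reported)
- compound 3 `Cc1ccc(C2CCN(CC(=O)Nc3cccc(C)c3)CC2)cc1`: "not active" (no number reported)

In a functional assay on cells for agonist activity at D(4) dopamine receptor (Homo sapiens), read by TR-FRET and cAMP accumulation, with a stated time of 30 min (on this read-out lower numbers stand for smaller maximal responses and higher numbers for larger maximal responses), compound 1 gives 27.8%, a small maximal response. Compound 2 gives "not active" (no number reported) in this assay, so no number stands for it; compound 3 likewise gives "not active" (no number reported) in this assay. Compound 2 thus sits at the inactive end of the set, with one further entry, compound 3, without a number beside it, and only compound 1 carrying a value at all.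

Compound 4 `O=C(CN1CCN(c2ccc(Cl)cn2)CC1)Nc1cccnc1` has not been measured in this assay. It differs from compound 2 in one place: pyridin-3-yl in place of 3-methylphenyl on an amide-type nitrogen. Within the data shown here, no measured pair shows the effect of this change, so no step can be quoted for it. With compound 2 at "not active" (no number reported) and the only numbered entry, compound 1, at 27.8%, the expectation is a small response at best, with no step beyond the scatter in either direction; the assay may well again report no number. The maximal response of compound 4 in this assay is estimated at 10%, within a range of 0% to 30%.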

Compound 4, largest response reached (Emax), in percent of the reference or control that the assay uses: "not active" (no number reported)
For compound 4 the study gives words and no number; there is nothing to compare the estimate with.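

Compound 2 and compound 4 both come without a number in this assay so no step can be read for pyridin-3-yl in place of 3-methylphenyl. The compounds shown leave open what this change does to a numbered maximal response. No other data bear on this result.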